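The source may report more compounds than this note shows. Statements on the series, on what has been measured and on what is new or still open speak of the compounds shown alone.

Compound 3 `Cc1c(C(=O)/C=C/c2ccc(Cl)cc2)[n+]([O-])c2ccccc2[n+]1[O-]` gives 19000 nM in a functional assay on HSC-4 cells (Homo sapiens) for cytotoxicity, with a stated time of 48 h; on this read-out lower numbers stand for higher toxicity in this test and higher numbers for lower toxicity in this test. Compound 2 `COc1ccc(/C=C/C(=O)c2c(C)[n+]([O-])c3ccccc3[n+]2[O-])cc1` gives 11000 nM in this assay, and compound 1 `Cc1c(C(=O)/C=C/c2cccc([N+](=O)[O-])c2)[n+]([O-])c2ccccc2[n+]1[O-]` gives 54000 nM. Swapping methoxy for chloro on an aromatic carbon gave a 1.7-fold higher number from compound 2 to compound 3 (0.24 log units; within the scatter). On these three numbers compound 3 holds the second highest, close to compound 2 and further from compound 1. Compound 4 `Cc1c(C(=O)/C=C/c2ccc(Cl)c(Cl)c2)[n+]([O-])c2ccccc2[n+]1[O-]` differs from compound 3 by chloro in place of hydrogen on an aromatic carbon, so the 4-chlorophenyl group becomes 3,4-dichlorophenyl. Among the measured compounds shown here, no measured step adds a second chloro; the only step that bears on it, a swap of one group for another at a single position, stayed within the scatter. Compound 4 is therefore expected to show a 1.3-fold lower number from compound 3 to compound 4 (0.10 log units; within the scatter), nothing beyond the scatter, with an estimated 15000 nM in a range from 6000 nM to 40000 nM.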

Compound 4, half-maximal cytotoxic concentration: 15000 nM
The estimate for compound 4 equals the measured number at the digits printed; the measured number falls inside the stated range.
By their numbers in this assay, from the lowest: compounds 2, 4 and 3 (each within the scatter of the next); then compound 1.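

Adding a second chloro in the place ortho to a chloro group and meta to a large group, in this assay, gave (a 1.3-fold lower number from compound 3 to compound 4 (0.10 log units; within the scatter)), the first read on this position. The 3,4-dichlorophenyl group also stays level with the 4-methoxyphenyl group (a 1.4-fold higher number from compound 2 to compound 4 (0.13 log units; within the scatter)), so the three compounds bearing these groups form one close cluster. No measurement here explains this closeness. The compounds shown leave open whether an amine or a carboxylic acid on this same aromatic carbon would also stay within the scatter of compound 3.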